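A few compounds are considered here, and "the series" means these few. Any claim that something is new, unique, unknown or untested is made for them only; others in the source may bear on it.

Working notes on the series, exposure after oral cassette dosing.

Two compounds carry a measurement. Compound 1 `C[C@H](c1ccc(-c2cc(Cl)ccc2-c2nc(=O)o[nH]2)cc1)N(CC1CC1)c1nc2c(C(=O)O)cccc2o1` gives, in an ADME assay on the whole organism (Macaca fascicularis) for pharmacokinetics, read by LC-MS, using cassette dosing, at a dose of 1 mg/kg by the oral route (on this read-out lower numbers stand for lower exposure and higher numbers for higher exposure at the dose given), 1300 ng.h/mL. Compound 2 `Cc1ccc(-c2nc(=O)o[nH]2)c(-c2ccc([C@@H](C)N(CC3CC3)c3nc4c(C(=O)O)cccc4o3)cc2)c1` gives in this assay 4830 ng.h/mL. Going by the values given here, the one measured step is a 3.7-fold higher number from compound 1 to compound 2 (0.57 log units; beyond the scatter), so compound 2 holds the higher of the two numbers, with compound 1 the only neighbour and distinctly below it.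

Compound 3 `C[C@H](c1ccc(-c2cc(F)ccc2-c2nc(=O)o[nH]2)cc1)N(CC1CC1)c1nc2c(C(=O)O)cccc2o1` is not yet measured. It differs from compound 2 by fluoro in place of methyl on an aromatic carbon. Among the compounds with values here, the only measured step that bears on this position is the one from compound 1 to compound 2, where chloro became methyl; the reverse of that step, methyl back to a halogen, is the nearest guide, though fluoro is not chloro and no step involving fluoro has been measured. A step in this assay from compound 2 to compound 3 of a 2.4-fold lower number from compound 2 to compound 3 (0.38 log units; beyond the scatter) is therefore expected, downward and likely beyond the scatter, but with wide uncertainty. For compound 3 the estimate in this assay is 2000 ng.h/mL, with a range from 700 ng.h/mL to 5500 ng.h/mL.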

Compound 3, area under the concentration-time curve: 4410 ng.h/mL
The estimate for compound 3 lay 2.2-fold (0.34 log units) below the measured number; the range from low to high includes it.
By their numbers in this assay, from the lowest: compound 1; then compounds 3 and 2 (each within the scatter of the next).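

Fluoro in place of methyl on this aromatic carbon gives, in this assay, a 1.1-fold lower number from compound 2 to compound 3 (0.04 log units; within the scatter), so the two groups cannot be told apart at this position on this read-out, which the single chloro-to-methyl step could not show. Fluoro in place of chloro gives a 3.4-fold higher number from compound 1 to compound 3 (0.53 log units; beyond the scatter), in the same direction as a 3.7-fold higher number from compound 1 to compound 2 (0.57 log units; beyond the scatter), and this makes the chloro compound the one that stands apart among the three: two different replacements of chloro both end beyond the scatter from compound 1, and the earlier step alone could not separate a gain tied to methyl from a difference shared by more than one replacement. Nothing measured here bears on the reason for this difference.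

Going by these compounds, whether the lower number in this assay belongs to chloro alone remains open, since a bromo or trifluoromethyl group at this place could fall with compound 1 or with compounds 2 and 3. A plain hydrogen, a methoxy or a nitrile at the same carbon would show how far the level shared by compounds 2 and 3 extends.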